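The source may report more compounds than this note shows. Statements on the series, on what has been measured and on what is new or still open speak of the compounds shown alone.

Of the compounds shown here, three have been measured in an assay on HEK293 cells for agonist activity at probable G-protein coupled receptor 34 (Mus musculus), with a stated time of 1 h; a lower number here means a smaller maximal response, a higher number a larger maximal response. Compound 1, `CCCCCCCC/C=C\CCCCCCCC(=O)OC[C@@H](COC)OP(=O)(O)OC[C@H](N)C(=O)O`, gives 12.9%. Compound 2, `CCCCCCCC/C=C\CCCCCCCC(=O)OC[C@@H](COCC)OP(=O)(O)OC[C@H](N)C(=O)O`, differs from compound 1 by methyl in place of hydrogen on a saturated chain carbon bound to an oxygen on a saturated carbon, and the measured step is a number 0.6 percentage points lower from compound 1 to compound 2 (within the scatter). Compound 3, `N[C@@H](COP(=O)(O)OCCOC(=O)CCc1ccccc1OCc1cccc(Oc2ccccc2)c1)C(=O)O`, is built on a different core; the difference between the two cores is not broken down here. In this assay compound 3 gives 12.4%, and compound 2 gives 12.3%, all three values lying within the scatter of one another.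

Compound 4, `C[C@H](COC(=O)CCc1ccccc1OCc1cccc(Oc2ccccc2)c1)OP(=O)(O)OC[C@H](N)C(=O)O`, has not yet been measured. It differs from compound 3 by methyl in place of hydrogen on a saturated chain carbon bound to an oxygen on an unsaturated carbon and a saturated chain carbon. For the measured compounds named here, this is the same kind of change as the one between compound 1 and compound 2, though not the same: there the carbon carrying the new methyl is bound to an oxygen on a saturated carbon, whereas here the oxygen sits on an unsaturated carbon and a saturated chain carbon. Because the earlier change gave a number 0.6 percentage points lower from compound 1 to compound 2 (within the scatter), a similarly small step is expected here. The expected step is no change at the digits printed from compound 3 to compound 4 (within the scatter). Compound 4 is therefore estimated to reach 12.4% in this assay.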

Compound 4, largest response reached (Emax), in percent of the reference or control that the assay uses: 12.4%
Beside the measured number, compound 4's estimate shows no gap at the digits printed; low and high end bracket the measured number.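

In this assay, the added methyl gives no change at the digits printed from compound 3 to compound 4 (within the scatter), and set beside the earlier case, the step looks alike on the two cores: the same change on two cores in this assay, a number 0.6 percentage points lower (within the scatter) from compound 1 to compound 2 and no change at the digits printed (within the scatter) from compound 3 to compound 4, 0.6 percentage points apart, within the scatter of two such steps. In these two pairs, then, the swap of hydrogen for methyl carries from one core to the other without a measurable difference in maximal response. For the compounds shown here, this does not show that the change is silent in general, since it rests on only two pairs, the carbon receiving the methyl has different surroundings in each, and neither step rises above the scatter, so the comparison would not reveal a small core-dependent effect.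

As far as these compounds go, it remains open whether a longer chain, an amine or a carboxylic acid in place of the methyl at this carbon would give a step beyond the scatter on either core. Also open, from the compounds shown here alone, is whether the same methyl would behave alike on a third core.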